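Methoxy Added to a Benzylsulfanyl Group: Expected Toxicity

The source may report more compounds than this note shows. Statements on the series, on what has been measured and on what is new or still open speak of the compounds shown alone.

Compound 1 `Cc1cc(N2CC[C@@H](C)[C@@H](N(C)c3ncnc4[nH]ccc34)C2)n2nc(SCc3ccccc3)nc2n1` gives, in a toxicity assay on GES1 cells (Homo sapiens) for inhibition, read by MTT assay, with a stated time of 72 h (a lower number here means a stronger inhibitor, a higher number a weaker inhibitor), a value of 67200 nM, the highest of the two plain numbers here; the nearest is compound 2 `Cc1cc(N2CC[C@@H](C)[C@@H](N(C)c3ncnc4[nH]ccc34)C2)n2ncnc2n1`, which gives 57900 nM, so that a 1.2-fold lower number from compound 1 to compound 2 (0.06 log units; within the scatter). Compound 3 `Cc1cc(N2CC[C@@H](C)[C@@H](N(C)c3ncnc4[nH]ccc34)C2)n2nc(SCc3ccc(F)c(Cl)c3)nc2n1` reports only a limit of the assay, > 100000 nM. Compound 4 `COc1ccc(CSc2nc3nc(C)cc(N4CC[C@@H](C)[C@@H](N(C)c5ncnc6[nH]ccc56)C4)n3n2)cc1` differs from compound 1 by methoxy in place of hydrogen on an aromatic carbon. The step that bears most on this is an at least 1.4-fold higher number from compound 1 to compound 3 (0.17 log units; that floor lies within the scatter), where another change on the same phenyl ring ended at the limit of > 100000 nM in this assay, at which 1 of the 3 values shown sits. Removing the whole benzylsulfanyl group also stayed within the scatter. For compound 4 a step no larger than the scatter is therefore expected, a 1.0-fold higher number from compound 1 to compound 4 (0.02 log units; within the scatter). Compound 4 is expected to give about 70000 nM, between 35000 nM and 140000 nM.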

Compound 4, half-maximal inhibitory concentration: > 100000 nM
Compound 4: no number, only a limit; the forecaster's own chance of this, stated with the estimate: 35%; middle value at least 1.4-fold (0.15 log units) away from the limit.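

Compound 4 gives only a limit of this assay, and this puts it with compound 3: the limit of > 100000 nM in this assay, at which 2 of the 4 values shown sit. The methoxy change shows an at least 1.4-fold higher number from compound 1 to compound 4 (0.17 log units; that floor lies within the scatter), and adding the whole (4-methoxybenzyl)sulfanyl group shows an at least 1.7-fold higher number from compound 2 to compound 4 (0.23 log units; that floor lies within the scatter), so a second substituent pattern on this phenyl ring also ends at the limit, though neither floor clears the scatter. The step between compound 3 and compound 4 cannot be read, as both values are limits.

From the compounds shown here alone, how far compound 3 and compound 4 truly lie from compound 1 stays open. So does the effect of an amine or a carboxylic acid on this ring.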